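Swapping ethoxy for methyl on the carbonyl of compound 3

The source may hold more compounds than are shown below. What is called first, only, known or untested is meant among the compounds shown, and "the series" means these compounds.

Of the compounds shown here, three sharing one core have been tested in an ADME assay on MT4 cells (Homo sapiens) for cytotoxicity, read by MTT assay; on this read-out lower numbers stand for higher toxicity in this test and higher numbers for lower toxicity in this test. Compound 1 `Cc1ccc(NC(=O)CSc2nncnc2-c2cccc3ccccc23)c([N+](=O)[O-])c1` gives 147000 nM in this assay. Going by the values given here, compound 2 `O=C(CSc1nncnc1-c1cccc2ccccc12)Nc1ccc(Cl)cc1Cl` gives 254000 nM; the step of a 1.7-fold higher number from compound 1 to compound 2 (0.24 log units; within the scatter) is the only single-point change measured so far. Compound 3 `CCOC(=O)c1ccc(NC(=O)CSc2nncnc2-c2cccc3ccccc23)c(Br)c1` gives 105000 nM, the lowest of the three numbers, close to compound 1 and somewhat further from compound 2.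

Compound 4 `CC(=O)c1ccc(NC(=O)CSc2nncnc2-c2cccc3ccccc23)c(Br)c1` has not yet been tested. It differs from compound 3 by methyl in place of ethoxy on a carbonyl carbon, a change on a carbonyl carbon whose other neighbour is an aromatic carbon. Among the compounds with values here, no measured step touches this carbonyl; the one step known concerns the group on the amide-type nitrogen and stayed within the scatter. With all three numbers lying close together, the expectation for compound 4 in this assay is 120000 nM, between 50000 nM and 300000 nM. The step this implies, a 1.1-fold higher number from compound 3 to compound 4 (0.06 log units; within the scatter), is expected to stay within the scatter.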

Compound 4, half-maximal cytotoxic concentration: 133000 nM
The estimate for compound 4 lay 1.1-fold (0.04 log units) below the measured number, within the range that was stated.
By their numbers in this assay, from the lowest: compounds 3, 4, 1 and 2 (each within the scatter of the next, the first and the last beyond it).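

In this assay, going by these compounds alone, the change from ethoxycarbonyl to acetyl gives a 1.3-fold higher number from compound 3 to compound 4 (0.10 log units; within the scatter) and is the first measured step at this carbonyl, one that leaves the two compounds no further apart than repeat measurements of a single compound could be. Setting 4-acetyl-2-bromophenyl on the amide-type nitrogen gives a 1.9-fold lower number from compound 2 to compound 4 (0.28 log units; within the scatter) when it replaces 2,4-dichlorophenyl and a 1.1-fold lower number from compound 1 to compound 4 (0.04 log units; within the scatter) when it replaces 4-methyl-2-nitrophenyl, so compound 4 cannot be told apart from any of the other three. Nothing available offers a reason for these small steps.

As far as these compounds go, how this assay would respond to a carboxylic acid or a primary amine in place of ethoxycarbonyl remains open. Also open, from the compounds shown here alone, is whether a longer chain on the carbonyl carbon would still give a step this small.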